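Swapping a Carbamate for a Fluoropyrimidine on the Ring Amine

The source may hold more compounds than are shown below. What is called first, only, known or untested is meant among the compounds shown, and "the series" means these compounds.

Measured compounds in a functional assay for agonist activity at Glucose-dependent insulinotropic receptor (Mus musculus), read by HTRF and cAMP accumulation, with a stated time of 45 min; on this read-out lower numbers stand for an effect already at smaller amounts and higher numbers for an effect only at larger amounts of compound:
compound 1 `CC(C)(C)OC(=O)N1CCN(c2ccc(OCc3ccc(S(C)(=O)=O)cc3)nn2)CC1` gives 1150 nM;
compound 2 `CC(C)(C)OC(=O)N1CCN(c2ccc(OCc3ccc(S(C)(=O)=O)cc3)cn2)CC1` gives 253 nM;
compound 3 `CC(C)OC(=O)N1CCN(c2ncc(OCc3ccncc3C#N)cn2)[C@H](C)C1` gives 458 nM.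

Compound 3 stands second highest of the three numbers: its value lies within the scatter of that of compound 2, while compound 1 gives a higher number beyond the scatter. Compound 4 `C[C@@H]1CN(c2ncc(F)cn2)CCN1c1ncc(OCc2ccncc2C#N)cn1` differs from compound 3 by 5-fluoropyrimidin-2-yl in place of isopropoxycarbonyl on an amine nitrogen in a ring. Within the data shown here, no two measured compounds differ in a single place, so no measured step speaks to this exchange. In this assay the change is expected to stay within the scatter, if anything tending slightly lower. Compound 4 is therefore estimated at 300 nM, ranging from 80 nM to 1200 nM. That estimate means an expected 1.5-fold lower number from compound 3 to compound 4 (0.18 log units; within the scatter).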

Compound 4, half-maximal effective concentration: 567 nM
For compound 4 the middle estimate is 1.9-fold (0.28 log units) below the measured one, within the range that was stated.
By their numbers in this assay, from the lowest: compounds 2, 3 and 4 (each within the scatter of the next, the first and the last beyond it); then compound 1.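

Among these compounds, replacing isopropoxycarbonyl with 5-fluoropyrimidin-2-yl on the amine nitrogen in the ring gives the first single-place step in this assay, a 1.2-fold higher number from compound 3 to compound 4 (0.09 log units; within the scatter), so this read-out does not tell the two groups apart. This position therefore accepts a six-membered aromatic ring in place of the open carbonyl-bearing group without a change beyond the scatter.

On these data alone, whether an unsubstituted pyrimidin-2-yl or a 5-chloropyrimidin-2-yl group on the same nitrogen would read alike remains open. Nothing measured here accounts for the result.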